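A Nitrile Swapped for a Larger Sulfur-Bearing Ring Group

This account rests on a few compounds, and the source may have more. Where it says the series, first, only, none or still open, it means among the compounds named here.

Within the data shown here, compound 1 `N#CCCn1nc(-c2ccccc2)ccc1=O` stands lowest of the two numbers so far in a functional assay on the whole organism (stomach) for inhibition, with Rattus norvegicus as the target, at a dose of 100 mg/kg by the intraduodenal route (a higher number here means more inhibition at the dose given (going by the name of the read-out), a lower number less inhibition), at 10.1%. Compound 2 `N=C(S)CCn1nc(-c2ccc(Cl)c(Cl)c2)ccc1=O` in this assay gives 55.8%, a value beyond the scatter above that of compound 1. Compound 3 `O=c1ccc(-c2ccccc2)nn1CCC(=S)N1CCCC1` is not yet measured; it differs from compound 1 by a group of 7 heavy atoms (5 carbon, 1 nitrogen, 1 sulfur; one five-membered non-aromatic ring with 1 hetero atom) in place of a group of 2 heavy atoms (1 carbon, 1 nitrogen; no ring), on a saturated chain carbon, two bonds along the chain from an aromatic nitrogen. Among the measured compounds shown here, no step between measured compounds is known, so the size of this change is uncertain. A moderate rise is expected a number 21.9 percentage points higher from compound 1 to compound 3 (beyond the scatter), since compound 2 also carries a sulfur-bearing group and gives 55.8%. Compound 3 is expected to give 32%, within 12% to 55%.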

Compound 3, a percentage reported as inhibition, in the whole organism at one dose (the size of the read-out at that dose, not a potency): 38.2%
The estimate for compound 3 lay 6.2 percentage points below the measured number; the measured number falls inside the stated range.
By their numbers in this assay, from the lowest: compound 1; then compound 3; then compound 2.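

At the saturated chain carbon, two bonds along the chain from an aromatic nitrogen, exchanging the cyano group for the sulfur-bearing five-membered ring group gives, in this assay, a number 28.1 percentage points higher from compound 1 to compound 3 (beyond the scatter). Among these compounds, with the shared core unchanged, this is the first comparison that ties a change in the number to this one position. No measurement bears on why the number moves.

Going by these compounds, the ring and the sulfur enter together, so which of them matters stays open. On these data alone, whether a carboxylic acid, an open-chain amine or a longer chain would serve at this place also remains open.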